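Swapping the Side Chain of an Aminoacyl-Sulfamoyl Adenosine

The source may hold more compounds than are shown below. What is called first, only, known or untested is meant among the compounds shown, and "the series" means these compounds.

Measured so far:
compound 1 `CSCC[C@H](N)C(=O)NS(=O)(=O)OC[C@H]1O[C@@H](n2cnc3c(N)ncnc32)[C@H](O)[C@@H]1O` — 500 nM
compound 2 `C[C@H](N)C(=O)NS(=O)(=O)OC[C@H]1OC[C@@H](n2cnc3c(N)ncnc32)C[C@@H]1O` — 5500 nM

Among the compounds with values here, of the two measured compounds, compound 1 gives the lower number in a functional assay on PBMC cells (Homo sapiens) for inhibition; on this read-out lower numbers stand for stronger inhibition and higher numbers for weaker inhibition; compound 2 sits at a number beyond the usual scatter above it, and no single-point step connects the pair. Compound 3 `CC(C)C[C@H](N)C(=O)NS(=O)(=O)OC[C@H]1O[C@@H](n2cnc3c(N)ncnc32)[C@H](O)[C@@H]1O` differs from compound 1 in one place: isopropyl in place of (methylsulfanyl)methyl on a saturated chain carbon, two bonds along the chain from an amine nitrogen and a carbonyl carbon. Within the data shown here, no measured pair shows what such a swap does here, so the step from compound 1 to compound 3 is expected to be modest, a 1.6-fold higher number from compound 1 to compound 3 (0.20 log units; within the scatter), with a slight lean toward weaker inhibition. Compound 3 is expected to give about 800 nM, between 150 nM and 4000 nM.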

Compound 3, half-maximal inhibitory concentration: 1100 nM
The estimate for compound 3 lay 1.4-fold (0.14 log units) below the measured number; the measured number falls inside the stated range.
By their numbers in this assay, from the lowest: compound 1; then compound 3; then compound 2.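

In this assay, isopropyl in place of (methylsulfanyl)methyl gives a 2.2-fold higher number from compound 1 to compound 3 (0.34 log units; beyond the scatter), so this side chain position does respond to the change, though modestly. The swap keeps the count of heavy atoms the same but removes the sulfur and its one hydrogen-bond acceptor, and compound 3 still gives a measurable number. Nothing available explains the shift.

Still open, from the compounds shown here alone, is how this position would respond to an amine, a carboxylic acid or a longer chain, any of which could move the number in either direction.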